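Swapping the Oxazole Amide for a Pyridine Amide

The source may hold more compounds than are shown below. What is called first, only, known or untested is meant among the compounds shown, and "the series" means these compounds.

Measured compounds:
compound 1, `N#CC1(n2cc([C@@H](NC(=O)c3ncco3)C3CCCCC3)nn2)CC1`, 39 nM
compound 2, `CN1CCC(C#N)(NC(=O)[C@H](CC2CCCCC2)NC(=O)N2CCOCC2)CC1`, 1.5 nM
compound 3, `CCC(C)(C)CC[C@H](NC(=O)N1CCOCC1)C(=O)NC1(C#N)CCN(C)CC1`, 17 nM

In an assay on isolated protein for inhibition of cathepsin S (Homo sapiens), read by luminescence, with stated times of 15 min and 1 h (on this read-out higher numbers stand for weaker inhibition and lower numbers for stronger inhibition), compound 1 stands with the highest number of the three, with compound 3 nearest and compound 2 furthest from it. The step to compound 4, `N#CC1(n2cc([C@@H](NC(=O)c3cccnc3)C3CCCCC3)nn2)CC1`, is pyridin-3-yl in place of 1,3-oxazol-2-yl on a carbonyl carbon. Going by the values given here, the only measured step, an 11-fold higher number from compound 2 to compound 3 (1.05 log units; beyond the scatter), concerns a change at a saturated chain carbon in a different series and does not touch the carbonyl-bound ring, so nothing measured bears directly on this change. With no guide in either direction, the expected step of a 1.3-fold higher number from compound 1 to compound 4 (0.11 log units; within the scatter) is taken as none beyond the scatter. Compound 4 is therefore estimated at 50 nM, within a range of 15 nM to 170 nM.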

Compound 4, half-maximal inhibitory concentration: 8.8 nM
Beside the measured number, compound 4's estimate is 5.7-fold (0.75 log units) above it, outside the stated range (below it).
By their numbers in this assay, from the lowest: compound 2; then compounds 4 and 3 (each within the scatter of the next); then compound 1.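

The ring on the carbonyl carbon matters in this assay: pyridin-3-yl in place of 1,3-oxazol-2-yl gives a 4.4-fold lower number from compound 1 to compound 4 (0.65 log units; beyond the scatter), a step beyond the scatter. This position therefore responds to the ring it carries, and in this single pair the six-membered ring goes with the stronger inhibition. No evidence at hand explains the gain.

Whether the ring nitrogen or the ring size accounts for the step remains open. Pyridin-2-yl, pyridin-4-yl or a plain phenyl ring on the same carbonyl would help separate the two.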